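Amino in Place of Methoxy: Cytotoxicity Outlook for Compound 3

The compounds below may be only part of what the source reports. "The series", "measured", "known", "first", "only" and "open" are said of these compounds alone.

Compound 1, `C[C@@]1(O)[C@H](O)[C@@H](CO)O[C@H]1n1cnc2c(N)nc(N=[N+]=[N-])nc21`: > 100000 nM
Compound 2, `COc1nc(O)nc2c1ncn2[C@@H]1O[C@H](CO)[C@@H](O)[C@@]1(C)O`: > 100000 nM

In an ADME assay on PBMC cells (Homo sapiens) for cytotoxicity, read by trypan blue exclusion, with a stated time of 6 days (on this read-out higher numbers stand for lower toxicity in this test and lower numbers for higher toxicity in this test), compound 1 gives > 100000 nM, which is a limit of the assay rather than a number. In this assay compound 2 gives > 100000 nM, again a limit and not a measured number. Compound 2 therefore stands at the limit of > 100000 nM in this assay, at which 2 of the 2 values shown sit, and nothing in the two values separates it from compound 1.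

The untested partner is compound 3, `C[C@@]1(O)[C@H](O)[C@@H](CO)O[C@H]1n1cnc2c(N)nc(O)nc21`. It differs from compound 2 in one place: amino in place of methoxy on an aromatic carbon. For the measured compounds named here, no step between two measured compounds is available to show what this change does in this assay, so the expectation rests only on where compound 2 sits. For compound 3 no step beyond the usual scatter is expected in this assay, as expressed by a number no higher from compound 2 to compound 3 (the limit leaves the size open). The most likely outcome for compound 3 is that this assay again reports a limit, and the estimated value is 100000 nM, with a range from 50000 nM to 200000 nM.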

Compound 3, half-maximal cytotoxic concentration: > 100000 nM
Compound 3: a limit, no number; the forecaster's own chance of this, stated with the estimate: 80%; the middle value lies on the limit itself.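

Compound 3 also ends at a limit rather than a number, so no step can be read from compound 2 to compound 3 or from compound 1 to compound 3 in this assay: the limit of > 100000 nM in this assay, at which 3 of the 3 values shown sit.

The compounds shown leave open whether amino in place of methoxy, or hydroxy in place of azido, changes the half-maximal cytotoxic concentration at all.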